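The compounds below may be only part of what the source reports. "The series", "measured", "known", "first", "only" and "open" are said of these compounds alone.

Compound 1, `O=C(Nc1ccc(Cl)c(Cl)c1)NS(=O)(=O)c1cc2ccccc2o1`: in a functional assay on the whole organism (Mus musculus) for inhibition, at a dose of 150 mg/kg by the oral route (a lower number here means less inhibition, a higher number more inhibition at the dose given (going by the name of the read-out)), compound 1 gives 28%.
Compound 2, `O=C(Nc1ccc(Br)cc1)NS(=O)(=O)c1cc2ccccc2o1`: in this assay compound 2 gives 48%.

For the measured compounds named here, of the two numbers so far, compound 2 stands highest. Going by the values given here, the only measured step, a number 20 percentage points higher from compound 1 to compound 2 (beyond the scatter), lies beyond the scatter and swaps one halogen pattern for another on the ring attached to the amide-type nitrogen. Compound 3, `Cc1ccc(NC(=O)NS(=O)(=O)c2cc3ccccc3o2)cc1`, has not yet been measured. It differs from compound 2 in one place: methyl in place of bromo on an aromatic carbon. Among the compounds with values here, no measured compound carries a methyl on that ring, so the one step on record does not speak directly to this change; it shows only that the numbers move when the substituents on that ring are altered. With no direct guide, a small downward step of a number 8 percentage points lower from compound 2 to compound 3 (within the scatter) is expected in this assay, one that may well stay within the scatter. Compound 3 is therefore estimated at 40%, with a range from 22% to 58%.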

Compound 3, a percentage reported as inhibition, in the whole organism at one dose (the size of the read-out at that dose, not a potency): 11%
The estimate for compound 3 lay 29 percentage points above the measured number; the whole stated range lies above it.
By their numbers in this assay, from the lowest: compound 3; then compound 1; then compound 2.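

Swapping bromo for methyl gives a number 37 percentage points lower from compound 2 to compound 3 (beyond the scatter) in this assay, so a change of a single heavy atom on this aromatic carbon, with no hydrogen-bond donor or acceptor entering or leaving, can still shift the read-out strongly. Compound 3 also sits under the dichlorinated compound, with a number 17 percentage points lower from compound 1 to compound 3 (beyond the scatter); among these three compounds, the two that carry halogen on this ring both give higher numbers than the one that carries methyl, and none goes against that pattern. Nothing measured here accounts for the size of these steps.

The compounds shown leave open how a methoxy group, an amine or a carboxylic acid on this carbon would fare. They also leave open whether a longer chain, such as ethyl, would stand nearer to methyl or to bromo.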